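Chloro to Cyano: What Clearance to Expect

This account rests on a few compounds, and the source may have more. Where it says the series, first, only, none or still open, it means among the compounds named here.

Three compounds have been run in an ADME assay on microsomes from liver (Mus musculus) for metabolic stability, read by LC-MS, with a stated time of 4 h, tested at 1 uM; on this read-out lower numbers stand for slow clearance and higher numbers for fast clearance. For compound 1 `CCOc1nc(Cl)cc(NC(=O)NCc2cc(C)c(-c3cn(C)nc3C(F)(F)F)nn2)c1C` this assay reports only a limit, < 534 mL/min/kg. For compound 2 `CCOc1nc(C#N)cc(NC(=O)NCc2cc(C)c(-c3cn(C)nc3C(F)(F)F)nn2)c1C` this assay again reports only a limit, < 164 mL/min/kg. Within the data shown here, compound 3 `CCOc1nc(C)cc(NC(=O)NCc2cc(C)c(-c3cn(C)nc3C(F)(F)F)nn2)c1Cl` gives the one actual number, 250 mL/min/kg. Compound 2 arises from compound 1 by cyano in place of chloro on an aromatic carbon, a step that the two limits leave unreadable from compound 1 to compound 2. Compound 3 differs from compound 1 in its core, (3-chloro-2-ethoxy-6-methylpyridin-4-yl in place of 6-chloro-2-ethoxy-3-methylpyridin-4-yl on an amide-type nitrogen), a step that the limit leaves unreadable from compound 1 to compound 3. Compound 4 `CCOc1nc(C)cc(NC(=O)NCc2cc(C)c(-c3cn(C)nc3C(F)(F)F)nn2)c1C#N` is not yet measured and arises from compound 3 by cyano in place of chloro on an aromatic carbon, the same kind of change, though here the place is ortho to an ethoxy group and two atoms from the ring nitrogen rather than next to the ring nitrogen. As the earlier step gives no readable size, compound 3 with 250 mL/min/kg is the only anchor for the expectation. The step is expected to be small, a 1.4-fold lower number from compound 3 to compound 4 (0.14 log units; within the scatter). Compound 4 is expected to give 180 mL/min/kg, estimated between 80 mL/min/kg and 400 mL/min/kg.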

Compound 4, clearance: 2270 mL/min/kg
For compound 4 the middle estimate is 13-fold (1.10 log units) below the measured one, and the stated range ends below it.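

In this assay cyano in place of chloro, ortho to an ethoxy group and two atoms from the ring nitrogen, brings a 9.1-fold higher number from compound 3 to compound 4 (0.96 log units; beyond the scatter) and so a clear rise in clearance on this one core. As far as these compounds go, the same change on the core of compound 1, leading to compound 2, cannot be read, as both compounds give only limits, so it stays unknown whether the change carries over from one core to the other, and one readable pair makes no rule for the series. Nothing measured here explains the rise.

Still open, from the compounds shown here alone, is how other groups would fare at this place on the core of compound 3, such as an amine, a carboxylic acid or a longer chain. Also open, going by these compounds, is whether the rise returns on any further core.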